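Swapping Imidazole for Pyrrole in a Nucleic Acid Binder

A few compounds are considered here, and "the series" means these few. Any claim that something is new, unique, unknown or untested is made for them only; others in the source may bear on it.

Compound 1 `CN(C)CCCNC(=O)c1cc(NC(=O)c2cc(NC(=O)c3nc(NC=O)cn3C)cn2CCCN)cn1C`: 0 degrees C
Compound 2 `CN(C)CCCNC(=O)c1cc(NC(=O)c2cc(NC(=O)c3nc(NC=O)cn3C)cn2C)cn1C`: 2 degrees C

For the measured compounds named here, in an assay on nucleic acid for binding affinity to Nucleic Acid, at pH 6.5, tested at 3 uM (on this read-out higher numbers stand for stronger stabilisation of the target against heat and lower numbers for weaker stabilisation of the target), compound 1 gives 0 degrees C, the lowest of the two numbers measured so far. Going by the values given here, compound 2 gives 2 degrees C in this assay, and the only measured step, a number 2.0 degrees C higher from compound 1 to compound 2 (beyond the scatter), comes from hydrogen in place of 2-aminoethyl on a saturated chain carbon bound to an aromatic nitrogen.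

Compound 3 `CN(C)CCCNC(=O)c1cc(NC(=O)c2cc(NC(=O)c3cc(NC=O)cn3C)cn2CCCN)cn1C` is built from compound 1 by a change at a different place: 4-(formylamino)-1-methyl-1H-pyrrol-2-yl in place of 4-(formylamino)-1-methyl-1H-imidazol-2-yl on a carbonyl carbon. Among the compounds with values here, no measured step touches the aromatic ring at this position, so the step from compound 1 to compound 2 offers no direct guide, and the expectation rests on the structural change alone. A small rise is expected, a number 1.0 degrees C higher from compound 1 to compound 3 (within the scatter), but it may well stay within the scatter. For compound 3 in this assay the estimate is 1 degrees C, with a range from -1 degrees C to 4 degrees C.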

Compound 3, shift of the target's melting temperature: 0 degrees C
Beside the measured number, compound 3's estimate is 1.0 degrees C above it, and the stated range covers the measured number.
By their numbers in this assay, from the lowest: compounds 1 and 3 (each within the scatter of the next); then compound 2.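

In this assay, 4-(formylamino)-1-methyl-1H-pyrrol-2-yl in place of 4-(formylamino)-1-methyl-1H-imidazol-2-yl on a carbonyl carbon gives no change at the digits printed from compound 1 to compound 3 (within the scatter). For the compounds shown here, this is the first measured change at this ring, and it shows that exchanging a ring with 2 hetero atoms for one with 1 hetero atom produces no difference that can be read in this compound pair. Since compound 1 already gives 0 degrees C, the pair has no measured stabilisation to lose, and nothing measured here offers an explanation for the result.

From the compounds shown here alone, it remains open whether the same exchange would also leave the number unchanged in compound 2, which gives 2 degrees C. It is also open how a phenyl ring or a furan ring at this place would read.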